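Lengthening the hydroxycarbamoyl chain by one step

The source may hold more compounds than are shown below. What is called first, only, known or untested is meant among the compounds shown, and "the series" means these compounds.

Compound 2 (`O=C(CCCOc1no[n+]([O-])c1S(=O)(=O)c1ccccc1)NO`) ends in a 3-(hydroxycarbamoyl)propyl chain. Among the compounds with values here, in a functional assay on ES2 cells (Homo sapiens) for inhibition, read by MTT assay, with a stated time of 48 h (a lower number here means a stronger inhibitor, a higher number a weaker inhibitor), compound 2 gives 3780 nM and this is the only number available. Compound 1 (`O=S(=O)(c1ccccc1)c1c(OCCCCCCO)no[n+]1[O-]`) shares the core, but compound 1 has the entry "not determined" (no result reported) and so offers no comparison.

Compound 3 (`O=C(CCCCOc1no[n+]([O-])c1S(=O)(=O)c1ccccc1)NO`) carries a 4-(hydroxycarbamoyl)butyl chain instead. The change is (hydroxycarbamoyl)methyl in place of hydroxycarbamoyl on a saturated chain carbon, three bonds along the chain from an oxygen on an aromatic ring.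

No measured step shows what such a change does among these compounds. The expectation therefore rests only on compound 2, at 3780 nM in this assay, and on the small size of the change. A modest gain in strength is expected, possibly not much beyond the usual scatter, and the estimated step is a 1.5-fold lower number from compound 2 to compound 3 (0.18 log units; within the scatter) in the same test. For compound 3 the estimate is 2500 nM, with an expected range from 850 nM to 6500 nM for the measurement.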

Compound 3, half-maximal inhibitory concentration: 2530 nM
Compound 3: the middle estimate sits 1.0-fold (0.01 log units) below what was measured; low and high end bracket the measured number.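

Within the data shown here, this is the first measured step at this place on the chain. Going from the 3-(hydroxycarbamoyl)propyl chain to the 4-(hydroxycarbamoyl)butyl chain gives a 1.5-fold lower number from compound 2 to compound 3 (0.17 log units; within the scatter) in this assay. The two compounds therefore cannot be told apart in this test, and the added chain step leaves the inhibition reading where repeated measurements alone could have placed it. Among these compounds, what the earlier compounds could not show is now on record: for this pair, swapping hydroxycarbamoyl for (hydroxycarbamoyl)methyl at this place, on a saturated chain carbon, brings no change that can be read beyond the scatter.

Going by these compounds, one step along a single chain says little about chain length in general, so it stays open whether a shorter 2-(hydroxycarbamoyl)ethyl chain, a longer 5-(hydroxycarbamoyl)pentyl chain, or a carboxylic acid at the chain end in place of the hydroxycarbamoyl group would read any differently on the shared core. Nothing shown alongside these compounds gives any account of what lies behind this result.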